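Estimating Compound 4 after Octyl Replaces Ethynyl

The source may report more compounds than this note shows. Statements on the series, on what has been measured and on what is new or still open speak of the compounds shown alone.

Compound 2 `C#Cc1ccc(S(=O)(=O)Nc2cccc(-c3csc(NC(C)=O)n3)c2)cc1` gives 38.3% in a functional assay on A-375 cells (Homo sapiens) for antiproliferative activity, read by trypan blue exclusion, with a stated time of 48 h, tested at 5 uM (on this read-out lower numbers stand for a stronger effect and higher numbers for a weaker effect at the one concentration tested), the highest of the three numbers recorded. Compound 3 `C#Cc1cccc(S(=O)(=O)Nc2cccc(-c3csc(NC(C)=O)n3)c2)c1` gives 29%, and compound 1 `CC(=O)Nc1nc(-c2cccc(NS(=O)(=O)c3ccc(Br)cc3)c2)cs1` gives 19.7%; the step of a number 9.3 percentage points lower from compound 2 to compound 3 (within the scatter) lies within the scatter, whereas a number 18.6 percentage points higher from compound 1 to compound 2 (beyond the scatter) lies beyond it. Compound 4 `CCCCCCCCc1ccc(S(=O)(=O)Nc2cccc(-c3csc(NC(C)=O)n3)c2)cc1` differs from compound 2 by octyl in place of ethynyl on an aromatic carbon. Among the measured compounds shown here, the one step touching this position that exceeds the scatter is a number 18.6 percentage points higher from compound 1 to compound 2 (beyond the scatter), showing that a change here can shift the number modestly. For the measured compounds named here, no measured compound carries an alkyl chain, so the direction of the new step is uncertain. Compound 4 is therefore expected to give 35%, within 15% to 60%. The expected step of a number 3.3 percentage points lower from compound 2 to compound 4 (within the scatter) is estimated to stay within the scatter.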

Compound 4, a percentage reported as activity, at one concentration (the size of the read-out at that concentration, not a potency): < 1%
Compound 4 was reported as a limit; the forecaster's own chance of this, stated with the estimate: 0%; middle value at least 34 percentage points from the limit.
By their numbers in this assay, from the lowest: compounds 1, 3 and 2 (each within the scatter of the next, the first and the last beyond it). At a limit, below all of these: compound 4.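

In this assay compound 4 gives < 1%, which is a limit and not a number. Until now a change on this aromatic carbon had shifted the number only modestly, but octyl brings a large step, a number at least 37.3 percentage points lower from compound 2 to compound 4 (beyond the scatter). It also goes past the bromo group of the best earlier value at this position, a number at least 18.7 percentage points lower from compound 1 to compound 4 (beyond the scatter), so a long alkyl chain here is compatible with a far stronger effect at the one concentration tested.

As far as these compounds go, whether a shorter chain such as butyl would do the same remains open. So does the effect of an octyl chain ending in an amine or a carboxylic acid.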